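A few compounds are considered here, and "the series" means these few. Any claim that something is new, unique, unknown or untested is made for them only; others in the source may bear on it.

Compound 1 `O=C(NS(=O)(=O)c1cc(Cl)c(Cl)s1)OC/C=C1\CCCc2cnn(Cc3ccc(Cl)cc3Cl)c21`: 5 nM
Compound 2 `COc1ccc(S(=O)(=O)NC(=O)NC/C=C2\CCCc3cnn(Cc4ccc(Cl)cc4Cl)c32)cc1`: 29 nM
Compound 3 `CS(=O)(=O)c1ccc(-n2ncc3c2/C(=C/CNC(=O)NS(=O)(=O)c2cc(Cl)c(Cl)s2)CCC3)cc1`: 30 nM

All three were tested in a functional assay on CHO-K1 cells for antagonist activity at prostaglandin E2 receptor EP3 subtype (Homo sapiens), read by TR-FRET and cAMP accumulation, with a stated time of 30 min; a lower number here means a stronger inhibitor, a higher number a weaker inhibitor. Compound 2 has the second highest of the three numbers; compound 3 sits alongside it, within the scatter, while compound 1 gives a number well below it, beyond the scatter. Compound 4 `COc1ccccc1S(=O)(=O)NC(=O)NC/C=C1\CCCc2cnn(Cc3ccc(Cl)cc3Cl)c21` has not yet been measured. It differs from compound 2 in one place: 2-methoxyphenyl in place of 4-methoxyphenyl on a sulfonyl sulfur. The same atoms are kept and merely joined differently. For the measured compounds named here, no measured pair shows what such a change does here, so only a modest step is expected, and it is estimated as a 1.4-fold higher number from compound 2 to compound 4 (0.14 log units; within the scatter), likely staying within the scatter. Compound 4 is expected to give about 40 nM in this assay, with a plausible range from 10 nM to 160 nM.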

Compound 4, half-maximal inhibitory concentration: 114 nM
For compound 4 the middle estimate is 2.9-fold (0.45 log units) below the measured one; low and high end bracket the measured number.
By their numbers in this assay, from the lowest: compound 1; then compounds 2 and 3 (each within the scatter of the next); then compound 4.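

Swapping 4-methoxyphenyl for 2-methoxyphenyl on a sulfonyl sulfur keeps the same atoms yet weakens inhibition (a 3.9-fold higher number from compound 2 to compound 4 (0.59 log units; beyond the scatter)). For the compounds shown here, this is the first single-change comparison, and it shows that activity here depends on how the methoxyphenyl group is joined, not only on which atoms are present. Nothing available explains this step. On these data alone, whether 3-methoxyphenyl in this place would track compound 2 or compound 4 stays open. So does whether 2-fluorophenyl would also give a weaker inhibitor than compound 2.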